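The source may report more compounds than this note shows. Statements on the series, on what has been measured and on what is new or still open speak of the compounds shown alone.

In a functional assay on KB cells (Homo sapiens) for cytotoxicity (a higher number here means that more compound is needed for the effect, a lower number that less compound is needed), compound 1 `COC1=C(C)C(=O)/C(=C(O)/C=C/c2cccc(OC)c2)C(=O)C1(C)C` gives 2.4 ug/mL, compound 2 `COC1=C(C)C(=O)/C(=C(O)/C=C/c2ccccc2OC)C(=O)C1(C)C` gives 2.8 ug/mL, and compound 3 `COC1=C(C)C(=O)/C(=C(O)/C=C/c2ccc(O)cc2)C(=O)C1(C)C` gives 3 ug/mL. These three share one core and differ only in the ring group on the chain. Compound 3 stands level with the other two, as its number cannot be told apart from theirs. The measured steps show this directly: a 1.3-fold higher number from compound 1 to compound 3 (0.10 log units; within the scatter), and a 1.1-fold higher number from compound 2 to compound 3 (0.03 log units; within the scatter). The remaining pair behaves the same way, with a 1.2-fold higher number from compound 1 to compound 2 (0.07 log units; within the scatter).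

Compound 4 `COC1=C(C)C(=O)/C(=C(O)/C=C/c2ccccc2C)C(=O)C1(C)C` has not yet been measured. Its difference from compound 3 is 2-methylphenyl in place of 4-hydroxyphenyl on a double-bonded chain carbon bound to a double-bonded chain carbon, with 2-methylphenyl in place of 4-hydroxyphenyl on a double-bonded chain carbon bound to a double-bonded chain carbon. Within the data shown here, no tested compound carries 2-methylphenyl, so the evidence is indirect. All three measured steps bear on the change. They swap the ring group at this same place, and each of them stayed within the scatter. Compound 2, with its 2-methoxyphenyl group, gives 2.8 ug/mL and is the nearest comparison by name.

In this assay, no step beyond the scatter is expected, and the estimated outcome is a 1.1-fold lower number from compound 3 to compound 4 (0.05 log units; within the scatter). The expected value for compound 4 is 2.7 ug/mL, with an estimated range from 1.4 ug/mL to 5.2 ug/mL.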

Compound 4, concentration for half-maximal effect: 1.6 ug/mL
Estimate against measurement, compound 4: 1.7-fold (0.23 log units) above; low and high end bracket the measured number.
By their numbers in this assay, from the lowest: compounds 4, 1, 2 and 3 (each within the scatter of the next).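

In this assay, 2-methylphenyl is the first ring group shown at this place with no oxygen on it, and putting it in place of 4-hydroxyphenyl gives a 1.9-fold lower number from compound 3 to compound 4 (0.27 log units; within the scatter). The closest swap, methyl in place of methoxy, gives a 1.8-fold lower number from compound 2 to compound 4 (0.24 log units; within the scatter), and the comparison with the 3-methoxyphenyl group gives a 1.5-fold lower number from compound 1 to compound 4 (0.18 log units; within the scatter), so across these four compounds an oxygen on this ring is not needed to keep the number within the scatter of the others. No measurement shown here offers a reason for how these ring groups act on the cells.

The ring groups shown are few and alike, so it stays open whether the number would hold with a ring carrying an amine or a carboxylic acid, or with a longer chain in place of the methyl. As far as these compounds go, it is also open whether the methyl group gives the same result elsewhere on the ring, as in 3-methylphenyl or 4-methylphenyl.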